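The source may hold more compounds than are shown below. What is called first, only, known or untested is meant among the compounds shown, and "the series" means these compounds.

Working notes on the series. Compound 1 `CCCc1ccc(C(=O)Nc2cccc(NC(=O)COc3ccc4c(=O)ccoc4c3)c2)cc1`, compound 2 `N#Cc1ccc(C(=O)Nc2cccc(NC(=O)COc3ccc4c(=O)ccoc4c3)c2)cc1` and compound 3 `CCOc1ccc(C(=O)Nc2cccc(NC(=O)COc3ccc4c(=O)ccoc4c3)c2)cc1` share one core and differ only in the group on the carbonyl carbon of the outer amide. In an assay on isolated protein for inhibition of Rho-associated protein kinase 2 (Homo sapiens), read by scintillation counting, radiometric assay and 33P incorporation, with a stated time of 40 min, in the presence of a further agent that is not named here (on this read-out lower numbers stand for stronger inhibition and higher numbers for weaker inhibition), compound 1 gives 14 nM, compound 2 gives 15 nM and compound 3 gives 9 nM. The three numbers sit together: a 1.1-fold higher number from compound 1 to compound 2 (0.03 log units; within the scatter), a 1.6-fold lower number from compound 1 to compound 3 (0.19 log units; within the scatter) and a 1.7-fold lower number from compound 2 to compound 3 (0.22 log units; within the scatter). Compound 3 therefore stands with the others, not apart from them.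

Compound 4 `Cc1cc(C(=O)Nc2cccc(NC(=O)COc3ccc4c(=O)ccoc4c3)c2)ccc1C(F)(F)F` is not yet measured. Against compound 3 the change is a group of 11 heavy atoms (8 carbon, 3 fluorine; one six-membered aromatic ring of carbon only) in place of a group of 9 heavy atoms (8 carbon, 1 oxygen; one six-membered aromatic ring of carbon only), on a carbonyl carbon. The three measured steps all bear on this position, and each of them stayed within the scatter, whether the exchanged group was propyl, cyano or ethoxy. On that basis the exchange for a ring carrying methyl and trifluoromethyl is expected to give no step beyond the scatter, i.e. a 1.3-fold higher number from compound 3 to compound 4 (0.12 log units; within the scatter) is expected. In this assay compound 4 is thus estimated at 12 nM, within a range of 5 nM to 30 nM.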

Compound 4, half-maximal inhibitory concentration: 43 nM
Compound 4: middle estimate off by 3.6-fold (0.55 log units), on the low side; measured number outside the range, above it.
By their numbers in this assay, from the lowest: compounds 3, 1 and 2 (each within the scatter of the next); then compound 4.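

In this assay the position on the carbonyl carbon proves sensitive to at least one exchange: the ring carrying methyl and trifluoromethyl gives a 4.8-fold higher number from compound 3 to compound 4 (0.68 log units; beyond the scatter) and a 2.9-fold higher number from compound 2 to compound 4 (0.46 log units; beyond the scatter) and a 3.1-fold higher number from compound 1 to compound 4 (0.49 log units; beyond the scatter) as the three steps to compound 4. All three run the same way and lie beyond the scatter, so compound 4 stands apart from compounds 1, 2 and 3, whose propyl, cyano and ethoxy groups remained within the scatter of one another. No measurement at hand accounts for this step.

Methyl and trifluoromethyl enter together in compound 4, so what each contributes alone stays open. Also open, on these data alone, is how this position responds to an amine or a carboxylic acid on the ring.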